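Aryl swap on the five-membered ring of compound 3

This account rests on a few compounds, and the source may have more. Where it says the series, first, only, none or still open, it means among the compounds named here.

Three compounds of the series have been run in a functional assay on CHO cells for agonist activity at Free fatty acid receptor 1 (Homo sapiens), read by FLIPR and calcium flux, tested at 100 nM; a higher number here means a stronger effect of the compound at the concentration tested, a lower number a weaker effect. Compound 1 `O=C(O)CC1COc2cc(OCc3csc(-c4ccccc4)n3)ccc21` gives 0.15%, and compound 2 `O=C(O)CC1COc2cc(OCc3cc(-c4ccccc4)on3)ccc21` gives 0.84%. Compound 3 `Cc1nc(-c2ccsc2)sc1COc1ccc2c(c1)OCC2CC(=O)O` gives 56.5% in this assay, the highest of the three numbers; its nearest neighbour is compound 2, a number lower by a gap beyond the scatter, and the furthest is compound 1, again beyond the scatter. No pair among these three differs in a single place, so no step between measured compounds can be read off.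

Compound 4 `Cc1nc(-c2ccccc2C(F)(F)F)sc1COc1ccc2c(c1)OCC2CC(=O)O` is the next member and has not yet been run in this assay. It differs from compound 3 in one place: 2-(trifluoromethyl)phenyl in place of thiophen-3-yl on an aromatic carbon. Going by the values given here, the core shared by compound 3 and compound 4 is otherwise unchanged, and no measured pair shows how a 2-(trifluoromethyl)phenyl compares with a thiophen-3-yl at this position.

Among the compounds with values here, with no directly comparable step available, the expectation for compound 4 rests on the signal of compound 3 at 56.5% and carries a wide range. Compound 4 is expected to give about 45% in this assay, within 10% to 80%. The step from compound 3 to compound 4 is thus estimated at a number 11.5 percentage points lower from compound 3 to compound 4 (beyond the scatter), a modest loss, which may well fall within the scatter.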

Compound 4, a percentage reported as activity, at one concentration (the size of the read-out at that concentration, not a potency): 7.76%
The estimate for compound 4 lay 37.2 percentage points above the measured number; measured number below the stated range.
By their numbers in this assay, from the lowest: compounds 1, 2 and 4 (each within the scatter of the next); then compound 3.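

In this assay, going by these compounds alone, replacing thiophen-3-yl with 2-(trifluoromethyl)phenyl on the aromatic carbon next to the ring nitrogen and next to the ring sulfur gives the first single-place step: a number 48.7 percentage points lower from compound 3 to compound 4 (beyond the scatter). Within the data shown here, with the rest of compound 3 held constant, the read-out at the tested concentration therefore depends strongly on the aryl group at this position, which the earlier compounds, differing from one another in more than one place, could not show. No measurement available here bears on the reason for a step of this size.

The step swaps the five-membered sulfur-containing aromatic ring for a six-membered carbon-only one and adds a trifluoromethyl group at once, so its two parts remain unseparated, and an unsubstituted phenyl at this position would be the comparison that divides them. The read-out also comes from a single concentration, so the compounds shown establish only a weaker effect of compound 4 at that concentration and leave open how strong its agonist effect would be at higher concentrations.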